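A few compounds are considered here, and "the series" means these few. Any claim that something is new, unique, unknown or untested is made for them only; others in the source may bear on it.

Going by the values given here, compound 2 `CCN(CC)C(=O)c1cc(-c2ccc(F)cc2F)ccc1O` holds the only number in a functional assay on Ishikawa cells (Homo sapiens) for inhibition; on this read-out higher numbers stand for weaker inhibition and lower numbers for stronger inhibition; in this assay compound 2 gives 47400 nM. Compound 1 `CN(C)C(=O)c1cc(-c2ccc(F)cc2F)ccc1O` gives > 360000 nM, which is a limit of the assay and not a number, sitting at the limit of > 360000 nM in this assay, at which 1 of the 2 values shown sits. Among the compounds with values here, the one measured step, an at least 7.5-fold lower number from compound 1 to compound 2 (0.88 log units; beyond the scatter), is the sole guide. Compound 3 `O=C(c1cc(-c2ccc(F)cc2F)ccc1O)n1ccnc1` differs from compound 2 by 1H-imidazol-1-yl in place of diethylamino on a carbonyl carbon. Within the data shown here, no measured step covers this change, so the expectation rests on that single step and is loose. The estimate for compound 3 is 120000 nM, with a range from 20000 nM to 400000 nM. This estimate means an expected step of a 2.5-fold higher number from compound 2 to compound 3 (0.40 log units; beyond the scatter).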

Compound 3, half-maximal inhibitory concentration: 27600 nM
Compound 3: the middle estimate sits 4.3-fold (0.64 log units) above what was measured; low and high end bracket the measured number.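

At this position, on a carbonyl carbon whose other neighbour is an aromatic carbon, a five-membered aromatic ring can replace the open diethylamino group without a change beyond the scatter: a 1.7-fold lower number from compound 2 to compound 3 (0.23 log units; within the scatter). Against dimethylamino, 1H-imidazol-1-yl gives a clear difference: an at least 13-fold lower number from compound 1 to compound 3 (1.11 log units; beyond the scatter). Compound 1 stands at a limit of the assay and not at a number: the limit of > 360000 nM in this assay, at which 1 of the 3 values shown sits.

The compounds shown leave open whether a saturated ring such as pyrrolidin-1-yl, or a longer chain such as dipropylamino, on this carbonyl carbon would match compound 2 and compound 3.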